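Swapping the Distal Aryl Group on a Shared Core

A few compounds are considered here, and "the series" means these few. Any claim that something is new, unique, unknown or untested is made for them only; others in the source may bear on it.

Of the compounds shown here, three sharing one core have been measured so far in an assay on isolated protein with Bile acid receptor (Homo sapiens) as the target; on this read-out lower numbers stand for an effect already at smaller amounts and higher numbers for an effect only at larger amounts of compound. Compound 1, `COC(=O)/C=C/c1cccc(N(Cc2ccc(/C=C/c3cccc(C(F)(F)F)c3)cc2)C(=O)C(C)C)c1`, gives 267 nM. Compound 2, `COC(=O)/C=C/c1cccc(N(Cc2ccc(-c3ccc(SC)cc3)cc2)C(=O)C(C)C)c1`, gives 51 nM, and compound 3, `COC(=O)/C=C/c1cccc(N(Cc2ccc(-c3ccc(OC)cc3)cc2)C(=O)C(C)C)c1`, gives 97 nM. Among these three numbers compound 3 stands second highest; its nearest neighbour is compound 2, its furthest compound 1. The two steps from compound 1 are both beyond the scatter: a 5.2-fold lower number from compound 1 to compound 2 (0.72 log units; beyond the scatter) and a 2.8-fold lower number from compound 1 to compound 3 (0.44 log units; beyond the scatter). The step between the two aryl compounds is not: a 1.9-fold higher number from compound 2 to compound 3 (0.28 log units; within the scatter).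

Compound 4, `COC(=O)/C=C/c1cccc(N(Cc2ccc(-c3cccc(C)c3)cc2)C(=O)C(C)C)c1`, has not yet been measured in this assay. It differs from compound 3 in one place: 3-methylphenyl in place of 4-methoxyphenyl on an aromatic carbon. The change sits on an aromatic carbon of a six-membered aromatic ring of carbon only, para to a large group. Among the compounds with values here, the only comparable step, from compound 2 to compound 3, exchanged one small substituent on that distal ring for another and stayed within the scatter. Compound 4 is therefore expected to give a number close to that of compound 3, with no step beyond the scatter, a 1.2-fold higher number from compound 3 to compound 4 (0.09 log units; within the scatter). The estimate for compound 4 in this assay is 120 nM, with a range from 50 nM to 300 nM.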

Compound 4, half-maximal effective concentration: 163 nM
Compound 4: middle estimate off by 1.4-fold (0.13 log units), on the low side; the measured number falls inside the stated range.
By their numbers in this assay, from the lowest: compounds 2, 3, 4 and 1 (each within the scatter of the next, the first and the last beyond it).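

In this assay, 3-methylphenyl in place of 4-methoxyphenyl gives a 1.7-fold higher number from compound 3 to compound 4 (0.23 log units; within the scatter), so this position on the distal ring accepts a group with no hydrogen-bond acceptor and a differently placed substituent without a change that can be told from the scatter. Within the data shown here, the same replacement set against the group of compound 1 gives a 1.6-fold lower number from compound 1 to compound 4 (0.21 log units; within the scatter), so unlike compound 2 and compound 3, compound 4 cannot be separated from compound 1, while a 3.2-fold higher number from compound 2 to compound 4 (0.50 log units; beyond the scatter) is the first exchange between two substituted phenyl groups at this position to go beyond the scatter. No measurement offered here speaks to why these numbers fall as they do.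

Compound 3 and compound 4 differ in both the substituent and its place on the ring, so these compounds cannot say which of the two matters, and a 3-methoxyphenyl or a 4-methylphenyl group would be needed to pull them apart. Also open is how this position responds to a distal ring bearing an amine or a carboxylic acid, as every substituent shown here is uncharged.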